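Swapping chloro for fluoro on a quinolone core: cytotoxicity outlook

The source may report more compounds than this note shows. Statements on the series, on what has been measured and on what is new or still open speak of the compounds shown alone.

Of the compounds shown here, three have been tested in an ADME assay on HEK293 cells (Homo sapiens) for cytotoxicity, read by luminescence, with a stated time of 72 h; on this read-out lower numbers stand for an effect already at smaller amounts and higher numbers for an effect only at larger amounts of compound. Compound 1 `CCOC(=O)c1c(-c2cccc(F)c2)[nH]c2cc(OC)ccc2c1=O` carries a 3-fluorophenyl group on the shared core. Compound 2 `CCOC(=O)c1c(-c2cccc(Cl)c2)[nH]c2cc(OC)ccc2c1=O` is its chloro counterpart. Compound 3 `CCOC(=O)c1c(-c2cccc(-c3ccccc3)c2)[nH]c2cc(OC)c(Cl)cc2c1=O` has a different core, and the difference between the two cores is not broken down here.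

In this assay compound 1 gives > 22000 nM, which is a limit of the assay and not a number. Compound 2 likewise gives only a limit, > 22000 nM. Compound 3 also reaches only a limit, > 22000 nM. The change from compound 2 to compound 1 is fluoro in place of chloro on an aromatic carbon, and the step it made is a step that the two limits leave unreadable from compound 2 to compound 1; the reason the step cannot be read is that (the limit of > 22000 nM in this assay, at which 3 of the 3 values shown sit).

Compound 4 `CCOC(=O)c1c(-c2cccc(-c3ccccc3)c2)[nH]c2cc(OC)c(F)cc2c1=O` has not yet been measured. It differs from compound 3 by fluoro in place of chloro on an aromatic carbon. Within the data shown here, this is the same kind of change as the one from compound 2 to compound 1, though the surroundings differ: in compound 4 the exchange sits on a ring that is part of a fused system of two rings, ortho to a methoxy group, meta to a fused ring and para to a fused ring, whereas in compound 1 it sits on a single ring, meta to a large group.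

Given that compound 3 gives > 22000 nM, the step from compound 3 to compound 4 is expected to be about a step that the limit leaves unreadable from compound 3 to compound 4. Compound 4 is therefore estimated at 30000 nM, most likely again only a limit.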

Compound 4, half-maximal effective concentration: > 22000 nM
Compound 4: a limit, no number; the forecaster's own chance of this, stated with the estimate: 85%; the middle value is on the limit's open side.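

Compound 4, like compound 3, gives only a limit in this assay, so no size can be read for the step between them, because the read-out stops at the same point for both: the limit of > 22000 nM in this assay, at which 4 of the 4 values shown sit. The compounds shown leave open whether fluoro in place of chloro on an aromatic carbon changes cytotoxicity at all, on either core, and at what concentration any of the four compounds would show an effect.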